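Trifluoromethoxy for butyl on the anilide of compound 3

The compounds below may be only part of what the source reports. "The series", "measured", "known", "first", "only" and "open" are said of these compounds alone.

Measured compounds:
compound 1 `CC(C)c1ccc(NC(=O)N2CCN(c3ncccc3[N+](=O)[O-])CC2)cc1` 190 nM
compound 2 `CC(C)c1ccc(NC(=O)N2CCN(c3ncccc3Br)CC2)cc1` 4.6 nM
compound 3 `CCCCc1ccc(NC(=O)N2CCN(c3ncccc3Cl)CC2)cc1` 117 nM

Of the compounds shown here, three share a core and have been tested in a functional assay on HEK293 cells for antagonist activity at transient receptor potential cation channel subfamily V member 1 (Rattus norvegicus); a lower number here means a stronger inhibitor, a higher number a weaker inhibitor. Compound 3 stands second highest of the three numbers; its nearest neighbour is compound 1, a gap within the scatter, while compound 2 lies furthest from it, well beyond the scatter. Going by the values given here, the only single-point step measured so far is a 41-fold lower number from compound 1 to compound 2 (1.62 log units; beyond the scatter), a change on the other aromatic ring, not the one altered here.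

Compound 4 `O=C(Nc1ccc(OC(F)(F)F)cc1)N1CCN(c2ncccc2Cl)CC1` differs from compound 3 by trifluoromethoxy in place of butyl on an aromatic carbon. Among the compounds with values here, no measured step touches this position, so nothing in the data says in which direction the number should move. Within the data shown here, compound 3 and compound 1 sit close together with different groups at that place, which suggests a change on this ring may matter less than the one from compound 1 to compound 2. Compound 4 is therefore expected to give about 80 nM (range 20 nM to 400 nM), a step of a 1.5-fold lower number from compound 3 to compound 4 (0.17 log units; within the scatter) that is estimated to stay near the scatter.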

Compound 4, half-maximal inhibitory concentration: 93.2 nM
The estimate for compound 4 lay 1.2-fold (0.07 log units) below the measured number, and the stated range covers the measured number.
By their numbers in this assay, from the lowest: compound 2; then compounds 4, 3 and 1 (each within the scatter of the next, the first and the last beyond it).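

In this assay, the first step measured at this position (a 1.3-fold lower number from compound 3 to compound 4 (0.10 log units; within the scatter)) exchanges butyl for trifluoromethoxy on the six-membered aromatic ring of carbon only and stays within the scatter. With chloro held on the other aromatic ring, an all-carbon chain and a group carrying oxygen and fluorine are therefore not told apart at this position, despite their different atoms and the hydrogen-bond acceptor that enters. Nothing available here bears on why these two groups are not separated.

On these data alone, whether an amine, a carboxylic acid or a longer chain at this position would also stay within the scatter remains open. So does whether the same exchange would hold with bromo or nitro on the other aromatic ring, where the one measured step is large (a 41-fold lower number from compound 1 to compound 2 (1.62 log units; beyond the scatter)).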